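Swapping the aryl group of a weak growth inhibitor

The source may report more compounds than this note shows. Statements on the series, on what has been measured and on what is new or still open speak of the compounds shown alone.

Within the data shown here, in a functional assay on DU-145 cells (Homo sapiens) for inhibition, read by trypan blue exclusion, with a stated time of 96 h (a higher number here means a weaker inhibitor of growth, a lower number a stronger inhibitor of growth), compound 2 `COc1ccc(/C=C(\C(=O)c2ccc(Br)cc2)S(=O)(=O)c2ccc(Br)cc2)c(OC)c1` gives 8000 nM, the higher of the two numbers measured so far. That makes it the weaker inhibitor of the pair, as compound 1 `O=C(/C(=C\c1ccc(I)cc1)S(=O)(=O)c1ccc(Br)cc1)c1ccc(Br)cc1` gives 1000 nM. Compound 3 `O=C(/C(=C\c1ccc(Br)c([N+](=O)[O-])c1)S(=O)(=O)c1ccc(Br)cc1)c1ccc(Br)cc1` has not been measured and changes the same group of compound 2: 4-bromo-3-nitrophenyl in place of 2,4-dimethoxyphenyl on a double-bonded chain carbon bound to a double-bonded chain carbon.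

Among the measured compounds shown here, only one measured step bears on this change. Replacing 4-iodophenyl with 2,4-dimethoxyphenyl at this place gives an 8.0-fold higher number from compound 1 to compound 2 (0.90 log units; beyond the scatter), a step beyond the usual scatter. Compound 3 also loses the 2,4-dimethoxyphenyl group, so it is expected to move back towards compound 1 at 1000 nM. For the measured compounds named here, this expectation rests on a single step, and the entering 4-bromo-3-nitrophenyl group has no measured precedent. The expected change is a 4.4-fold lower number from compound 2 to compound 3 (0.65 log units; beyond the scatter), towards stronger inhibition. The estimated value for compound 3 is 1800 nM, within an expected range of 500 nM to 6500 nM.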

Compound 3, concentration for 50% growth inhibition: 10000 nM
Estimate against measurement, compound 3: 5.6-fold (0.74 log units) below, outside the stated range (above it).
By their numbers in this assay, from the lowest: compound 1; then compounds 2 and 3 (each within the scatter of the next).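

In this assay, 4-bromo-3-nitrophenyl and 2,4-dimethoxyphenyl cannot be told apart on this double-bonded chain carbon: the swap gives a 1.3-fold higher number from compound 2 to compound 3 (0.10 log units; within the scatter) at this place. Removing 2,4-dimethoxyphenyl is therefore not enough to bring the number down, and 4-iodophenyl is the only group shown that stands apart, with a 10-fold higher number from compound 1 to compound 3 (1.00 log units; beyond the scatter) for the exchange of that group. No measured evidence explains why these groups compare as they do.

The compounds shown leave open whether 4-iodophenyl is unusual here, or whether a plain phenyl ring or a phenyl ring carrying an amine or a carboxylic acid would also give a number as low as that of compound 1. They also leave open whether the advantage of 4-iodophenyl would hold on a different core.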